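The source may hold more compounds than are shown below. What is called first, only, known or untested is meant among the compounds shown, and "the series" means these compounds.

Compound 1 `O=C(Nc1cccc(-c2oc3cc(-c4ccc(F)cc4)ccc3c(=O)c2O)c1)c1ccc(Br)cc1`: 8630 nM
Compound 2 `O=C(Nc1cccc(-c2oc3cc(-c4ccc(F)cc4)ccc3c(=O)c2O)c1)c1ccc(Cl)nc1`: 7550 nM
Compound 3 `O=C(Nc1cccc(-c2oc3cc(-c4ccc(F)cc4)ccc3c(=O)c2O)c1)c1cc(F)cc(F)c1`: 2070 nM

The three measured compounds share one core and differ only in the aryl group on the carbonyl carbon of the amide. In a functional assay on HCC1937 cells (Homo sapiens) for antiproliferative activity, read by CCK-8 assay, with a stated time of 72 h (a lower number here means a stronger inhibitor, a higher number a weaker inhibitor), compound 1 gives 8630 nM, the highest of the three numbers. Compound 2 lies within the scatter of it, a 1.1-fold lower number from compound 1 to compound 2 (0.06 log units; within the scatter), whereas compound 3 lies beyond it, a 4.2-fold lower number from compound 1 to compound 3 (0.62 log units; beyond the scatter), a modest step.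

Compound 4 `O=C(Nc1cccc(-c2oc3cc(-c4ccc(F)cc4)ccc3c(=O)c2O)c1)c1ccc([N+](=O)[O-])cc1` has not yet been measured in this assay. It differs from compound 1 by nitro in place of bromo on an aromatic carbon. Within the data shown here, no measured step exchanges one substituent for another on that aromatic carbon; the two steps from compound 1 each replace the whole 4-bromophenyl group, and both show that such changes in this part of the molecule move the number only modestly, one within the scatter and one beyond it. Compound 4 is therefore expected to stay close to compound 1, with a step of a 1.3-fold lower number from compound 1 to compound 4 (0.12 log units; within the scatter) that most likely lies within the scatter. The estimated value for compound 4 is 6500 nM, with a range from 2500 nM to 16000 nM.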

Compound 4, half-maximal inhibitory concentration: 5640 nM
Estimate against measurement, compound 4: 1.2-fold (0.06 log units) above; low and high end bracket the measured number.
By their numbers in this assay, from the lowest: compound 3; then compounds 4, 2 and 1 (each within the scatter of the next).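

In this assay, exchanging bromo for nitro on an aromatic carbon, para to a large group, with the ring itself kept, gives a 1.5-fold lower number from compound 1 to compound 4 (0.18 log units; within the scatter), so this substituent exchange on that carbon stays within the scatter. Replacing the 6-chloropyridin-3-yl group with the 4-nitrophenyl group also stays within the scatter, a 1.3-fold lower number from compound 2 to compound 4 (0.13 log units; within the scatter), whereas replacing the 3,5-difluorophenyl group with it does not, a 2.7-fold higher number from compound 3 to compound 4 (0.44 log units; beyond the scatter), and among the four aryl groups only 3,5-difluorophenyl stands apart. Nothing measured here bears on why the numbers fall this way.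

From the compounds shown here alone, it remains open whether an amine, a carboxylic acid or a methoxy group on that same aromatic carbon would stay within this band. Going by these compounds, a single fluoro there is equally open, including whether it would bring the number towards that of compound 3.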